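Methyl to Hydrogen on an Aromatic Oxygen: Compound 4

The compounds below may be only part of what the source reports. "The series", "measured", "known", "first", "only" and "open" are said of these compounds alone.

Measured compounds:
compound 1 `COc1cc(-c2nn(-c3cccc(NC(=O)Nc4cc(C(F)(F)F)cc(C(F)(F)F)c4)c3)cc2-c2ccncc2)ccc1Cl` > 50000 nM
compound 2 `COc1cc(-c2nn(-c3cccc(NC(=O)Nc4ccc(Cl)c(Cl)c4)c3)cc2-c2ccncc2)ccc1Cl` > 50000 nM
compound 3 `O=C(Nc1cccc(-n2cc(-c3ccncc3)c(-c3ccc(Cl)c(O)c3)n2)c1)Nc1ccc(Cl)c(Cl)c1` > 32500 nM

In a functional assay on MOLT-4 cells (Homo sapiens) for inhibition, read by sulforhodamine B assay, with a stated time of 48 h (on this read-out higher numbers stand for lower toxicity in this test and lower numbers for higher toxicity in this test), compound 1 gives > 50000 nM, which is a limit of the assay and not a number. Compound 2 gives > 50000 nM, again a limit. Compound 3 gives > 32500 nM, also a limit. The difference between the cores of compound 1 and compound 2 is not broken down here. Compound 3 differs from compound 2 by hydrogen in place of methyl on an oxygen on an aromatic ring, and this gave a step that the two limits leave unreadable from compound 2 to compound 3. Compound 4 `O=C(Nc1cccc(-n2cc(-c3ccncc3)c(-c3ccc(Cl)c(O)c3)n2)c1)Nc1cc(C(F)(F)F)cc(C(F)(F)F)c1` differs from compound 1 by the same change, (hydrogen in place of methyl on an oxygen on an aromatic ring). All three readings are limits, two at the limit of > 50000 nM in this assay, at which 2 of the 3 values shown sit, and one at the limit of > 32500 nM in this assay, at which 1 of the 3 values shown sits, so no direction can be read from them.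

The expected step is a step that the limit leaves unreadable from compound 1 to compound 4 because a step that the two limits leave unreadable from compound 2 to compound 3 shows no readable change for the same alteration. Compound 4 is estimated at 60000 nM. Compound 4 is expected to fall between 30000 nM and 150000 nM, most probably again as a limit.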

Compound 4, concentration lethal to 50% of the cells: > 50000 nM
Compound 4: no number, only a limit; the forecaster's own chance of this, stated with the estimate: 85%; the middle value lies beyond the limit too.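

In this assay compound 4 gives > 50000 nM, a limit and not a number. Compound 1 gives > 50000 nM, also a limit, so no step can be read between compound 1 and compound 4. The compounds shown leave open whether the change from methoxy to hydroxy has any effect in this assay, and in which direction.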